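This account rests on a few compounds, and the source may have more. Where it says the series, first, only, none or still open, it means among the compounds named here.

Measured so far:
compound 1, `C=C1C(=O)OC[C@H]1CCOC(=O)Nc1ccc(C(C)C)cc1`: 12400 nM
compound 2, `C=C1C(=O)OC[C@H]1CCOC(=O)Nc1ccccc1`: 14800 nM
compound 3, `C=C1C(=O)OC[C@@H]1CCOC(=O)Nc1ccc(I)cc1`: 12500 nM

In an ADME assay on RAW264.7 cells (Mus musculus) for cytotoxicity, read by MTT assay, with a stated time of 18 h (a higher number here means that more compound is tolerated, a lower number that less compound is tolerated), compound 3 stands second highest of the three numbers, but all three lie within the scatter of one another, so no order can be read from them. Compound 4, `C=C1C(=O)OC[C@@H]1CCOC(=O)Nc1ccc(C(C)C)cc1`, is the next step: isopropyl in place of iodo on an aromatic carbon. Among the compounds with values here, the only measured step on this ring, a 1.2-fold higher number from compound 1 to compound 2 (0.08 log units; within the scatter), was within the scatter, and compound 1 already carries the isopropyl group with 12400 nM. From this, no step beyond the scatter is expected in this assay, in either direction. Compound 4 is therefore estimated at 12500 nM, with a range from 7000 nM to 22000 nM, a step of no change at the digits printed from compound 3 to compound 4 (within the scatter) that is expected to stay within the scatter.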

Compound 4, half-maximal cytotoxic concentration: 15300 nM
For compound 4 the middle estimate is 1.2-fold (0.09 log units) below the measured one; the range from low to high includes it.
By their numbers in this assay, from the lowest: compounds 1, 3, 2 and 4 (each within the scatter of the next).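

Putting isopropyl in place of iodo on the aromatic carbon gives a 1.2-fold higher number from compound 3 to compound 4 (0.09 log units; within the scatter), so in this assay these two groups cannot be told apart at this position. Within the data shown here, the first comparison of the drawn stereocentre gives a 1.2-fold higher number from compound 1 to compound 4 (0.09 log units; within the scatter), so reversing it leaves no readable difference either. That comparison isolates the stereocentre alone: the fact that compounds 1 and 4 differ only in the configuration as drawn

As far as these compounds go, whether an amine or a carboxylic acid on that aromatic carbon would give a step beyond the scatter remains open. Every step shown so far lies within the scatter, so no change yet separates these compounds.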